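A few compounds are considered here, and "the series" means these few. Any claim that something is new, unique, unknown or untested is made for them only; others in the source may bear on it.

Three compounds share a coumarin-like core carrying an oxygen-linked three-carbon chain with a hydroxyl group and a terminal nitrogen. Compound 1 `COc1ccccc1N1CCN(CC(O)COc2ccc3oc(=O)cc(C)c3c2)CC1` bears an aryl-substituted piperazine on that chain, and in a functional assay on ileum for antagonist activity at histamine H1 receptor (Cavia porcellus), tested at 0.1 mg/mL (a lower number here means that less compound is needed, a higher number that more compound is needed for the effect), compound 1 gives 0.0058 ug/mL. Compound 2 `CCCNCC(O)COc1ccc2c(-c3ccccc3)cc(=O)oc2c1` carries a propylamino end instead; in this assay compound 2 gives 0.0056 ug/mL. Compound 3 `O=c1cc(-c2ccccc2)c2ccc(OCC(O)CN3CCNCC3)cc2o1` has an unsubstituted piperazine, and in this assay compound 3 gives 0.0058 ug/mL, level with compound 1 at the digits shown and within the scatter of compound 2 as well. Within the data shown here, the one step that changes the chain end, a 1.0-fold higher number from compound 2 to compound 3 (0.02 log units; within the scatter), stays within the scatter.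

Compound 4 `O=c1cc(-c2ccccc2)c2ccc(OCC(O)CN3CCN(c4ccccc4)CC3)cc2o1` differs from compound 3 by phenyl in place of hydrogen on an amine nitrogen in a ring. Among the measured compounds shown here, no measured step alters that piperazine nitrogen directly; compound 1, which already carries an aryl group there on a differently substituted core, lies within the scatter of compound 3. The change is therefore expected to give a 1.0-fold higher number from compound 3 to compound 4 (0.01 log units; within the scatter), nothing beyond the scatter. Compound 4 is estimated at 0.006 ug/mL, ranging from 0.003 ug/mL to 0.012 ug/mL.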

Compound 4, half-maximal effective concentration: 0.0054 ug/mL
Estimate against measurement, compound 4: 1.1-fold (0.05 log units) above, and the stated range covers the measured number.
By their numbers in this assay, from the lowest: compounds 4, 2, 1 and 3 (each within the scatter of the next).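

In this assay, phenyl in place of hydrogen on the amine nitrogen in the ring gives a 1.1-fold lower number from compound 3 to compound 4 (0.03 log units; within the scatter), so this large aromatic group leaves the number within the scatter. Among these compounds, this is the first direct reading at this nitrogen with the rest of the molecule held the same; compound 1 also carries an aryl group there, but its core differs, so it could not show the effect of this change alone. Nothing measured here explains why the number holds.

From the compounds shown here alone, whether a benzyl or acetyl group on the same nitrogen, or a carboxylic acid on the phenyl ring, would also stay within the scatter remains open. All the compounds shown lie within the scatter of one another, so it is also unknown what kind of group at this nitrogen could shift the number at all.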